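Sulfonamide nitrogen substitution across two cores

The source may report more compounds than this note shows. Statements on the series, on what has been measured and on what is new or still open speak of the compounds shown alone.

Compound 1, `N=C(N)NS(=O)(=O)c1ccc(/N=C/c2c(Cl)c3ccccc3oc2=O)cc1`, gives 180 nM in a functional assay on B16-F10 cells (Mus musculus) for cytotoxicity, read by CCK-8 assay, with a stated time of 48 h; on this read-out higher numbers stand for weaker inhibition and lower numbers for stronger inhibition.
Compound 2, `Cc1cc(C)nc(NS(=O)(=O)c2ccc(/N=C/c3c(Cl)c4ccccc4oc3=O)cc2)n1`, gives 170 nM in this assay.
Compound 3, `CC(C)(C)c1cc(C(C)(C)C)c2oc(=O)c(/C=N/c3ccc(S(=O)(=O)NC(=N)N)cc3)c(Cl)c2c1`, gives 250 nM in this assay.

Compound 1 and compound 2 share a core and differ in one place: a group of 8 heavy atoms (6 carbon, 2 nitrogen; one six-membered aromatic ring with 2 hetero atoms) in place of a group of 3 heavy atoms (1 carbon, 2 nitrogen; no ring), on a sulfonamide nitrogen. The result was a 1.1-fold lower number from compound 1 to compound 2 (0.02 log units; within the scatter). Compound 3 carries a different core; the difference between the core of compound 1 and the core of compound 3 is not broken down here. In this assay the three values lie within the scatter of one another, so no order among compound 1, compound 2 and compound 3 is claimed.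

Compound 4, `Cc1cc(C)nc(NS(=O)(=O)c2ccc(/N=C/c3c(Cl)c4cc(C(C)(C)C)cc(C(C)(C)C)c4oc3=O)cc2)n1`, is not yet measured. It relates to compound 3 as compound 2 relates to compound 1: a group of 8 heavy atoms (6 carbon, 2 nitrogen; one six-membered aromatic ring with 2 hetero atoms) in place of a group of 3 heavy atoms (1 carbon, 2 nitrogen; no ring), on a sulfonamide nitrogen. The place is the same word for word in both pairs, so this is the same change made on a second core. Within the data shown here, only one measured instance of the change exists, and it was within the scatter. Compound 4 is therefore expected to give 230 nM in this assay, an expected step of a 1.1-fold lower number from compound 3 to compound 4 (0.04 log units; within the scatter), with a range from 120 nM to 450 nM. The expectation for compound 4 is essentially no change because a 1.1-fold lower number from compound 1 to compound 2 (0.02 log units; within the scatter) lay within the scatter, and a single instance on one core gives nothing firmer for a second core.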

Compound 4, half-maximal inhibitory concentration: 220 nM
For compound 4 the middle estimate is 1.0-fold (0.02 log units) above the measured one, within the range that was stated.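

In this assay, 4,6-dimethylpyrimidin-2-yl in place of the group it replaces on the sulfonamide nitrogen gave a 1.1-fold lower number from compound 3 to compound 4 (0.06 log units; within the scatter), and this step can be set beside the earlier step on the other core: the same change on two cores in this assay, a 1.1-fold lower number (0.02 log units; within the scatter) from compound 1 to compound 2 and a 1.1-fold lower number (0.06 log units; within the scatter) from compound 3 to compound 4, 1.1-fold (0.03 log units) apart, within the scatter of two such steps. On these two pairs the change therefore carries from one core to the other without a readable difference, and on neither core does it move the number beyond the scatter. Among these compounds, this shows only that the two groups are interchangeable on these two cores in this one cell read-out; with just two pairs, and both steps within the scatter, it does not show that the change would behave the same way on a further core, nor does it test whether a step beyond the scatter would carry over.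

Still open, on these data alone, is whether a plain hydrogen, an acetyl group, an amine-bearing chain or a carboxylic acid on the sulfonamide nitrogen would give a step beyond the scatter on either core. Also open, as far as these compounds go, is whether the pattern would hold on a core with methoxy groups or bromine in place of the tert-butyl groups of compound 3 and compound 4.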